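Swapping a methylthiophene for phenyl on a shared amide core

The compounds below may be only part of what the source reports. "The series", "measured", "known", "first", "only" and "open" are said of these compounds alone.

Of the compounds shown here, three built on the same core have been tested in a functional assay on A549 cells (Homo sapiens) for antiproliferative activity, read by MTT assay, with a stated time of 48 h; on this read-out higher numbers stand for weaker inhibition of growth and lower numbers for stronger inhibition of growth. Compound 1, with the structure `CCOc1cc(NC(=O)CCCCC(=O)Nc2cc(-c3ccc(C)s3)ccc2N)cc2c1OCC([N+](=O)[O-])=C2`, gives 13800 nM. It is the highest of the three numbers, so it is the weakest grower-inhibitor of the set. Compound 2, `CCOc1cc(NC(=O)CCCCCC(=O)Nc2cc(-c3ccc(C)s3)ccc2N)cc2c1OCC([N+](=O)[O-])=C2`, gives 5070 nM in this assay, and compound 3, `CCOc1cc(NC(=O)CCCCCCC(=O)Nc2cc(-c3ccc(C)s3)ccc2N)cc2c1OCC([N+](=O)[O-])=C2`, gives 5830 nM. Both of these differ from compound 1 in the length of the chain joining the two amide groups, and both stand beyond the scatter below compound 1.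

Compound 4, `CCOc1cc(NC(=O)CCCCC(=O)Nc2cc(-c3ccccc3)ccc2N)cc2c1OCC([N+](=O)[O-])=C2`, is not yet measured in this assay. It keeps the chain of compound 1 and changes only the aromatic group: phenyl in place of 5-methylthiophen-2-yl on an aromatic carbon. The place is on an aromatic carbon of a six-membered aromatic ring of carbon only, meta to a large group and para to an amino group.

Going by the values given here, no measured pair in this set shows what such a swap does. A change of one aromatic ring for another of the same size, with no other change, is expected to move the number only a little, likely no further than the scatter, in either direction. For compound 4 the expected step of a 1.2-fold lower number from compound 1 to compound 4 (0.06 log units; within the scatter) is therefore small, and compound 4 is estimated at 12000 nM, within a range from 4500 nM to 35000 nM.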

Compound 4, concentration for 50% growth inhibition: 7460 nM
Beside the measured number, compound 4's estimate is 1.6-fold (0.21 log units) above it; the measured number falls inside the stated range.
By their numbers in this assay, from the lowest: compounds 2, 3, 4 and 1 (each within the scatter of the next, the first and the last beyond it).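

In this assay, going by these compounds alone, this is the first direct reading of the position, and the swap gives a 1.8-fold lower number from compound 1 to compound 4 (0.27 log units; within the scatter) with the chain left unchanged. That step lies within the usual scatter, so on this chain the assay does not separate phenyl from 5-methylthiophen-2-yl at this aromatic carbon, and a five-membered aromatic ring with a sulfur atom can give way to a six-membered ring of carbon only without a change that can be read. No measurement here speaks to how either ring acts on the cells.

The compounds shown leave open whether phenyl would give the same result on the chains of compound 2 and compound 3, since this swap is read only on the chain of compound 1. They also leave open how this position would respond to a group of a different kind, such as a pyridine ring, a carboxylic acid or an amine, or to a ring carrying a substituent such as a fluorine atom.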